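The compounds below may be only part of what the source reports. "The series", "measured", "known", "first", "only" and "open" are said of these compounds alone.

Measured compounds:
Compound 1 `CCCN(CCC)c1nc(N2CCN(C(=O)c3ccco3)[C@@H]3CCCC[C@@H]32)nc2cc(OC)c(OC)cc12` gives 0.129 nM in an assay on CHO cells for displacement of a labelled ligand from Alpha-1B adrenergic receptor (Homo sapiens), with a stated time of 30 min; on this read-out lower numbers stand for stronger inhibition and higher numbers for weaker inhibition.
Compound 2 `COc1cc2nc(N3CCN(C(=O)C(C)(C)C)[C@H]4CCCC[C@H]43)nc(N)c2cc1OC` gives 0.776 nM in the same this assay.

Going by the values given here, of the two numbers seen so far in this assay, compound 2 stands at the higher one, the weaker of the pair, and its only neighbour, compound 1, sits beyond the scatter below it. Compound 3 `COc1cc2nc(N3CCN(C(=O)OCc4ccccc4)[C@H]4CCCC[C@H]43)nc(N)c2cc1OC` is the new, not yet measured compound. It departs from compound 2 at a single place: benzyloxy in place of tert-butyl on a carbonyl carbon. Among the compounds with values here, no pair among the measured compounds shows this kind of change, so there is no measured step to lean on, and the expected shift is small. The account therefore expects a step of a 1.6-fold lower number from compound 2 to compound 3 (0.19 log units; within the scatter) in this assay, at most a slightly lower number and likely nothing beyond the scatter. For compound 3 the estimated value in this assay is 0.5 nM, within a range from 0.15 nM to 2 nM.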

Compound 3, inhibition constant: 0.38 nM
Beside the measured number, compound 3's estimate is 1.3-fold (0.12 log units) above it; the range from low to high includes it.
By their numbers in this assay, from the lowest: compound 1; then compound 3; then compound 2.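

Going by these compounds alone, on the carbonyl carbon whose other neighbour is the amide-type nitrogen in a ring, benzyloxy in place of tert-butyl gives a 2.0-fold lower number from compound 2 to compound 3 (0.31 log units; beyond the scatter) in this assay and this is the first measured step at this place, a modest one. It shows that this place accepts a group of 8 heavy atoms, with an aromatic ring and a hydrogen-bond acceptor, where 4 heavy atoms stood before, with no loss on this read-out. Nothing measured here gives a reason for the step.

The compounds shown leave open whether the oxygen or the phenyl ring of benzyloxy carries the step, which a benzyl group on the same carbonyl carbon would help to separate. On these data alone, how an amine or a longer alkyl chain would read at this place also remains open.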